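Trifluoromethyl to tert-butyl on the thiazole of compound 3

The source may report more compounds than this note shows. Statements on the series, on what has been measured and on what is new or still open speak of the compounds shown alone.

Measured compounds:
Compound 1 `CC(C)[C@H](C(=O)Nc1ccc(F)cn1)c1ccc(Cl)cc1`: 93%
Compound 2 `Cc1csc(NC(=O)[C@H](c2ccc(Cl)cc2)C(C)C)n1`: 87%
Compound 3 `CC(C)[C@H](C(=O)Nc1nc(C(F)(F)F)cs1)c1ccc(Cl)cc1`: 123%

In a functional assay on CHO cells for agonist activity at Free fatty acid receptor 2 (Homo sapiens), read by cAMP accumulation (a higher number here means a larger maximal response, a lower number a smaller maximal response), compound 3 gives 123%, the highest of the three, with compound 1 the nearest and compound 2 the furthest, both beyond the scatter. Compound 4 `CC(C)[C@H](C(=O)Nc1nc(C(C)(C)C)cs1)c1ccc(Cl)cc1` differs from compound 3 by tert-butyl in place of trifluoromethyl on an aromatic carbon. The step that bears on this position is a number 36 percentage points higher from compound 2 to compound 3 (beyond the scatter), a large gain on the same aromatic carbon. Among the measured compounds shown here, no measured step replaces trifluoromethyl with tert-butyl, so the direction is open; a moderate change in either direction seems possible. Compound 4 is therefore expected to give 105%, between 80% and 130%, meaning an estimated step of a number 18 percentage points lower from compound 3 to compound 4 (beyond the scatter).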

Compound 4, largest response reached (reported as efficacy), in percent of the reference or control that the assay uses: 45%
Beside the measured number, compound 4's estimate is 60 percentage points above it, and the stated range ends above it.
By their numbers in this assay, from the lowest: compound 4; then compounds 2 and 1 (each within the scatter of the next); then compound 3.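

In this assay, this ring carbon next to the ring nitrogen does not only allow gains: a number 78 percentage points lower from compound 3 to compound 4 (beyond the scatter), although trifluoromethyl and tert-butyl have the same heavy-atom count. The loss also holds against methyl, as a number 42 percentage points lower from compound 2 to compound 4 (beyond the scatter), so at this carbon the maximal response depends on the group's identity, not on that count alone. Nothing available explains this drop. On these data alone, whether an amine, a methoxy group or a carboxylic acid on this carbon would stay near compound 3 or fall towards compound 4 remains open.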